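Swapping the Amide Group of Compound 1

The source may report more compounds than this note shows. Statements on the series, on what has been measured and on what is new or still open speak of the compounds shown alone.

Compound 1 `C/C(=C\c1ccc(NC(=O)Nc2ccc(Cl)c(C(F)(F)F)c2)cc1)C(=O)NC(C)c1ccccc1` was tested in a functional assay on MX1 cells (Homo sapiens) for inhibition, read by MTT assay, with a stated time of 120 h; a higher number here means a weaker inhibitor, a lower number a stronger inhibitor. In this assay compound 1 gives only a limit of the assay, > 50000 nM, and no number.

A true number exists for compound 2 `CC(NC(=O)c1ccc(-c2ccc(NC(=O)Nc3ccc(Cl)c(C(F)(F)F)c3)cc2)cc1)c1ccccc1`, which reads 4630 nM in this assay.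

Compound 3 `C/C(=C\c1ccc(NC(=O)Nc2ccc(Cl)c(C(F)(F)F)c2)cc1)C(=O)N1CC(C)OC(C)C1` keeps the core of compound 1 and alters one group: 2,6-dimethylmorpholin-4-yl in place of (1-phenylethyl)amino on a carbonyl carbon. Here 2,6-dimethylmorpholin-4-yl stands in place of (1-phenylethyl)amino on a carbonyl carbon.

Among the measured compounds shown here, no measured pair shows the size of this change, so the expectation starts from the limit of compound 1 at > 50000 nM. The expected step of an at least 1.1-fold lower number from compound 1 to compound 3 (0.04 log units; that floor lies within the scatter) is small, with at most a slight move toward a stronger inhibitor in this assay. Compound 3 is estimated at 45000 nM, within an expected range from 12000 nM to 100000 nM.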

Compound 3, half-maximal inhibitory concentration: > 50000 nM
Compound 3: a limit, no number; the forecaster's own chance of this, stated with the estimate: 55%; at least 1.1-fold (0.04 log units) between middle value and limit.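

No step can be read between compound 1 and compound 3, as each gives only a limit and no number: the limit of > 50000 nM in this assay, at which 2 of the 3 values shown sit.

The compounds shown leave open how far either lies past that limit, and so whether 2,6-dimethylmorpholin-4-yl in place of (1-phenylethyl)amino on a carbonyl carbon changes inhibition at all.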